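Methyl in Place of Fluoro on the Thiourea Aryl Ring

The source may hold more compounds than are shown below. What is called first, only, known or untested is meant among the compounds shown, and "the series" means these compounds.

Compound 1, `O=C(NC(=S)Nc1ccc(F)cc1)c1cn(-c2ccccc2)nc1-c1ccc(F)cc1`: 3540 nM
Compound 2, `COc1ccc(-c2nn(-c3ccccc3)cc2C(=O)NC(=S)Nc2ccc(F)cc2)cc1`: 1430 nM
Compound 3, `O=C(NC(=S)Nc1ccc(F)cc1)c1cn(-c2ccccc2)nc1-c1ccc(Cl)cc1`: 3980 nM

All three compounds were tested in a functional assay on A549 cells (Homo sapiens) for inhibition, read by CCK-8 assay, with a stated time of 48 h; on this read-out lower numbers stand for stronger inhibition and higher numbers for weaker inhibition. Among them, compound 1 holds the second highest number. Its nearest neighbour is compound 3, and that step, a 1.1-fold higher number from compound 1 to compound 3 (0.05 log units; within the scatter), stays within the scatter of the method. Going by the values given here, the only clearly separated value belongs to compound 2, reached by the step of a 2.5-fold lower number from compound 1 to compound 2 (0.39 log units; beyond the scatter).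

Compound 4, `Cc1ccc(NC(=S)NC(=O)c2cn(-c3ccccc3)nc2-c2ccc(F)cc2)cc1`, differs from compound 1 in a single place: methyl in place of fluoro on an aromatic carbon. Read one bond further out, the (4-fluorophenyl)amino group of compound 1 becomes a (4-methylphenyl)amino group in compound 4.

Neither measured step bears directly on this change. Both a 2.5-fold lower number from compound 1 to compound 2 (0.39 log units; beyond the scatter) and a 1.1-fold higher number from compound 1 to compound 3 (0.05 log units; within the scatter), together with a 2.8-fold higher number from compound 2 to compound 3 (0.44 log units; beyond the scatter), alter the other aromatic ring, the one bound to the shared core, and leave the thiourea aryl untouched. What they show is that swapping one small group for another on an aromatic ring in this series moves the number only modestly at most, and sometimes not beyond the scatter.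

Compound 4 is therefore expected to sit near compound 1, with the step of a 1.1-fold lower number from compound 1 to compound 4 (0.04 log units; within the scatter) expected to fall within the scatter. The estimated value for compound 4 is 3200 nM, with a range from 1300 nM to 8000 nM.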

Compound 4, half-maximal inhibitory concentration: 2080 nM
Compound 4: middle estimate off by 1.5-fold (0.19 log units), on the high side, and the stated range covers the measured number.
By their numbers in this assay, from the lowest: compounds 2, 4, 1 and 3 (each within the scatter of the next, the first and the last beyond it).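

This is the first change shown on the thiourea aryl ring, and in this assay it gives a 1.7-fold lower number from compound 1 to compound 4 (0.23 log units; within the scatter). Putting methyl in place of fluoro at this ring carbon, para to a large group, therefore produces no separable change in the number, so this one pair offers no sign that the choice between these two single-atom groups matters here. The data shown offer no measurement that could explain this outcome.

The compounds shown leave open whether a quite different group at the same place, such as an amine, a carboxylic acid or a longer chain, would move the number beyond the scatter. Going by these compounds, it also remains open whether methoxy on this ring would have an effect like the one seen on the other aromatic ring, a 2.5-fold lower number from compound 1 to compound 2 (0.39 log units; beyond the scatter), and with only fluoro and methyl compared here, the reach of this single result is narrow.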